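The source may hold more compounds than are shown below. What is called first, only, known or untested is meant among the compounds shown, and "the series" means these compounds.

Compound 1 `Cc1ccc2occ(C3N=C(c4ccccc4)SS3)c(=O)c2c1` gives 67% in a functional assay on A549 cells (Homo sapiens) for inhibition, read by sulforhodamine B assay, with a stated time of 48 h, tested at 100 uM (on this read-out higher numbers stand for more inhibition of growth at the one concentration tested and lower numbers for less inhibition of growth), the highest of the two numbers measured in this series. For the measured compounds named here, compound 2 `O=c1c(C2N=C(c3ccccc3)SS2)coc2ccc(F)cc12` gives 55% in this assay, and the only step measured so far, fluoro in place of methyl on an aromatic carbon, is a number 12 percentage points lower from compound 1 to compound 2 (beyond the scatter). Compound 3 `O=c1c(C2N=C(c3ccccc3)SS2)coc2ccccc12` is not yet measured; it differs from compound 1 by hydrogen in place of methyl on an aromatic carbon. The measured step bears on this change only loosely, since it swaps methyl for fluoro rather than removing it, and it was modest. Compound 3 is therefore expected to come out somewhat below compound 1, a step of about a number 10 percentage points lower from compound 1 to compound 3 (within the scatter), with a possible outcome within the scatter. The estimate for compound 3 in this assay is 57%, between 42% and 70%.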

Compound 3, percent growth inhibition at one concentration: 42%
Estimate against measurement, compound 3: 15 percentage points above; the measured number falls inside the stated range.
By their numbers in this assay, from the lowest: compound 3; then compound 2; then compound 1.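

Hydrogen in place of methyl on this aromatic carbon gives a number 25 percentage points lower from compound 1 to compound 3 (beyond the scatter) in this assay, so the methyl of compound 1 counts for more here than the earlier swap for fluoro could show. Hydrogen in place of fluoro gives a number 13 percentage points lower from compound 2 to compound 3 (beyond the scatter), which puts compound 3, without a substituent at this carbon, below both substituted compounds. Nothing at hand accounts for this order.

Open, from the compounds shown here alone, is how a methoxy group, a chlorine or an amine on this same carbon would rank against the methyl of compound 1. Also open, going by these compounds, is whether the order holds on the other carbons of this ring.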